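Swapping tert-butyl for piperidinyl on a chalcone

The compounds below may be only part of what the source reports. "The series", "measured", "known", "first", "only" and "open" are said of these compounds alone.

Compound 2 `CC(C)(C)c1ccc(C(=O)/C=C/c2ccco2)cc1` is a chalcone-type compound whose aryl ketone carries a tert-butyl group. In an ADME assay on THP-1 cells (Homo sapiens) for cytotoxicity, read by resazurin assay, with a stated time of 72 h (on this read-out lower numbers stand for higher toxicity in this test and higher numbers for lower toxicity in this test), compound 2 gives > 50000 nM, which is a limit of the assay rather than a number. Its nitro-bearing partner, compound 1 `CC(C)(C)c1ccc(C(=O)/C=C/c2ccc([N+](=O)[O-])o2)cc1`, is a close relative. In this assay compound 1 gives > 50000 nM, again a limit. The step that the two limits leave unreadable from compound 1 to compound 2 therefore cannot be read. A third relative, compound 3 `O=C(/C=C/c1cccc([N+](=O)[O-])c1)c1ccc(N2CCCCC2)cc1`, already carries the piperidinyl group. In this assay compound 3 gives > 50000 nM, also a limit. All three compounds sit at the limit of > 50000 nM in this assay, at which 3 of the 3 values shown sit.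

Compound 4 `O=C(/C=C/c1ccco1)c1ccc(N2CCCCC2)cc1` differs from compound 2 by piperidin-1-yl in place of tert-butyl on an aromatic carbon. Going by the values given here, no measured step shows what this swap does to toxicity, since every value so far is a limit; still, compound 3, which holds the same piperidinyl group, also gave only a limit. Compound 4 is therefore expected to show the step that the limit leaves unreadable from compound 2 to compound 4, which means no change beyond the scatter. The estimate for compound 4 in this assay is 60000 nM, with a range from 20000 nM to 200000 nM.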

Compound 4, half-maximal cytotoxic concentration: > 50000 nM
Compound 4 was reported as a limit (the forecaster's own chance of this, stated with the estimate: 80%); the middle value does not contradict the limit.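

In this assay compound 4 gives > 50000 nM, which is a limit and not a number. Going by these compounds alone, compound 2 also stands at a limit, so no step to compound 4 can be read. The compounds shown leave open whether piperidin-1-yl in place of tert-butyl changes toxicity at all.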